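Piperidine nitrogen substituent changes in the shared core series

The compounds below may be only part of what the source reports. "The series", "measured", "known", "first", "only" and "open" are said of these compounds alone.

Measured so far, all in a functional assay on CHO-K1 cells for agonist activity at Glucose-dependent insulinotropic receptor (Homo sapiens), read by a luciferase reporter, with a stated time of 5 h; a lower number here means that less compound is needed, a higher number that more compound is needed for the effect:
compound 1 `CC(C)COC(=O)N1CCC(Oc2ncnc3c2CCN3c2ccc(S(C)(=O)=O)cc2F)CC1`, compound 1 gives 25.1 nM
compound 2 `COCCOC(=O)N1CCC(Oc2ncnc3c2CCN3c2ccc(S(C)(=O)=O)cc2F)CC1`, compound 2 gives 316 nM
compound 3 `CS(=O)(=O)c1ccc(N2CCc3c(OC4CCN(C(=S)Sc5ccccc5)CC4)ncnc32)c(F)c1`, compound 3 gives 12.6 nM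

Compound 3 has the lowest number of the three in this assay. Its nearest neighbour is compound 1, with a 2.0-fold lower number from compound 1 to compound 3 (0.30 log units; within the scatter), a step within the scatter, so the two cannot be ordered. Compound 2 sits furthest away, with a 25-fold lower number from compound 2 to compound 3 (1.40 log units; beyond the scatter). Within the carbamates, a 13-fold higher number from compound 1 to compound 2 (1.10 log units; beyond the scatter) shows that the group on the amine nitrogen in the ring carries a large part of the activity in this series.

Compound 4 `CC(C)c1noc(N2CCC(Oc3ncnc4c3CCN4c3ccc(S(C)(=O)=O)cc3F)CC2)n1` differs from compound 3 as follows: a group of 8 heavy atoms (5 carbon, 2 nitrogen, 1 oxygen; one five-membered aromatic ring with 3 hetero atoms) in place of a group of 9 heavy atoms (7 carbon, 2 sulfur; one six-membered aromatic ring of carbon only), on an amine nitrogen in a ring. Among the measured compounds shown here, no measured step involves the 3-isopropyl-1,2,4-oxadiazol-5-yl group, so the expectation rests on the three neighbours. The two steps that change this same position, a 2.0-fold lower number from compound 1 to compound 3 (0.30 log units; within the scatter) and a 25-fold lower number from compound 2 to compound 3 (1.40 log units; beyond the scatter), show that a change here can be either within the scatter or large. Given that compound 1 and compound 3 lie within the scatter of each other, compound 4 is expected to land near them, with a modest step of a 2.0-fold higher number from compound 3 to compound 4 (0.30 log units; within the scatter) estimated in this assay, not clearly beyond the scatter. The estimate for compound 4 is 25 nM, with a range from 6 nM to 100 nM.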

Compound 4, half-maximal effective concentration: 79.4 nM
Compound 4: the middle estimate sits 3.2-fold (0.50 log units) below what was measured; measured number inside the range.
By their numbers in this assay, from the lowest: compounds 3 and 1 (each within the scatter of the next); then compound 4; then compound 2.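

In this assay, the 3-isopropyl-1,2,4-oxadiazol-5-yl group shows that the amine nitrogen in the ring can carry a five-membered aromatic ring with 3 hetero atoms directly, whereas compounds 1, 2 and 3 all hold a carbonyl or thiocarbonyl group at this place. This replacement does not act in one direction: against the isobutoxycarbonyl group it gives a 3.2-fold higher number from compound 1 to compound 4 (0.50 log units; beyond the scatter), and against the (2-methoxyethoxy)carbonyl group it gives a 4.0-fold lower number from compound 2 to compound 4 (0.60 log units; beyond the scatter), while the change from the group in compound 3 gives a 6.3-fold higher number from compound 3 to compound 4 (0.80 log units; beyond the scatter), so among the four compounds a carbonyl or thiocarbonyl group at this place is not required for activity, and compound 2 goes against any reading that it always gives the lower number. No measurement at hand accounts for these steps.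

The compounds shown leave open how much of the number for compound 4 depends on the isopropyl group on the ring, a question that a cyclopropyl or tert-butyl group there would address. They also leave open how a six-membered aromatic ring with nitrogen, such as a pyrimidine, would compare when bound directly to the same amine nitrogen.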